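A few compounds are considered here, and "the series" means these few. Any claim that something is new, unique, unknown or untested is made for them only; others in the source may bear on it.

In a functional assay on HL-60 cells (Homo sapiens) for inhibition, read by MTT assay, with a stated time of 72 h (a higher number here means a weaker inhibitor, a lower number a stronger inhibitor), compound 3 `Cc1nc(-c2ccccc2)c(C(=O)N2CCN(c3cccc(C)c3C)CC2)o1` gives 35 nM, the lowest of the two numbers reported in this series. Compound 1 `Cc1nc(-c2ccccc2F)c(C(=O)N2CCN(c3cc(Cl)ccc3C)CC2)o1` gives 229 nM in this assay, a higher number than that of compound 3, and the gap between the two lies beyond the usual scatter. For compound 2 `COc1cccc(N2CCN(C(=O)c3oc(C(F)(F)F)nc3-c3cccc(F)c3)CC2)c1` the outcome in this assay is recorded as "not active" (no number reported), with no number attached.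

Compound 4 `Cc1nc(-c2ccccc2)c(C(=O)N2CCN(c3ccc(C)c(C)c3)CC2)o1` has not yet been measured. It differs from compound 3 in one place: 3,4-dimethylphenyl in place of 2,3-dimethylphenyl on an amine nitrogen in a ring. The same atoms are present in both, joined differently. Among the compounds with values here, no pair of measured compounds shows this kind of rearrangement, so the size of the step is uncertain. The change is expected to cost a little in this assay, giving a step from compound 3 to compound 4 of a 2.0-fold higher number from compound 3 to compound 4 (0.30 log units; within the scatter), which may well fall within the scatter. Compound 4 is therefore estimated at 70 nM in this assay, with a range from 20 nM to 250 nM.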

Compound 4, half-maximal inhibitory concentration: 43 nM
Beside the measured number, compound 4's estimate is 1.6-fold (0.21 log units) above it, and the stated range covers the measured number.
By their numbers in this assay, from the lowest: compounds 3 and 4 (each within the scatter of the next); then compound 1.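

In this assay the exchange of 2,3-dimethylphenyl for 3,4-dimethylphenyl on the amine nitrogen in the ring gives a 1.2-fold higher number from compound 3 to compound 4 (0.09 log units; within the scatter) and so lies within the scatter, which means that this rearrangement of the same atoms does not separate the two compounds in this assay. The earlier compounds shown here differed from one another in more than one place, so they could not show how this position responds to the arrangement of the two methyl groups alone. No measurement shown here bears on why the two arrangements read alike.

On these data alone, it remains open whether the number would stay in this range with an amine, a methoxy group or a carboxylic acid on the phenyl ring in place of the methyl groups. Within the data shown here, it also remains open whether this result carries over to cores other than the one shared by compound 3 and compound 4.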